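A carboxyphenyl group takes the imidazolyl group's place

A few compounds are considered here, and "the series" means these few. Any claim that something is new, unique, unknown or untested is made for them only; others in the source may bear on it.

Compound 1 `O=C(O)c1cncc(CN2CCC[C@H](O[C@H](CO)c3cc(Cl)cc(Cl)c3)[C@@H]2c2ccccc2)c1`: 14 10^-6 cm/s
Compound 2 `OC[C@@H](O[C@H]1CCCN(Cc2ncc[nH]2)[C@H]1c1ccccc1)c1cc(Cl)cc(Cl)c1`: 19 10^-6 cm/s

Both compounds were tested in an ADME assay on MDCK-II cells (Canis lupus familiaris) for permeability; a higher number here means that the compound crosses the layer faster, a lower number that the compound crosses the layer more slowly. Only these two numbers exist so far, and compound 2 lies within the usual scatter of compound 1, so neither can be ranked above the other.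

Compound 3 `O=C(O)c1ccc(CN2CCC[C@H](O[C@H](CO)c3cc(Cl)cc(Cl)c3)[C@@H]2c2ccccc2)cc1` has not been measured yet. It differs from compound 2 as follows: 4-carboxyphenyl in place of 1H-imidazol-2-yl on a saturated chain carbon bound to an amine nitrogen in a ring. In short, 4-carboxyphenyl stands in place of 1H-imidazol-2-yl on a saturated chain carbon bound to an amine nitrogen in a ring.

Within the data shown here, one measured step bears on this: a 1.4-fold higher number from compound 1 to compound 2 (0.13 log units; within the scatter). There, 1H-imidazol-2-yl replaced 5-carboxypyridin-3-yl at the same place, so the new change runs roughly the opposite way. The expected result is a 1.4-fold lower number from compound 2 to compound 3 (0.13 log units; within the scatter), with no shift beyond the scatter. For compound 3 the estimated value is 14 10^-6 cm/s, with an expected range from 7 10^-6 cm/s to 27 10^-6 cm/s.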

Compound 3, apparent permeability: 16 10^-6 cm/s
Compound 3: middle estimate off by 1.1-fold (0.06 log units), on the low side; low and high end bracket the measured number.
By their numbers in this assay, from the lowest: compounds 1, 3 and 2 (each within the scatter of the next).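

In this assay, putting 4-carboxyphenyl in place of 1H-imidazol-2-yl gives a 1.2-fold lower number from compound 2 to compound 3 (0.07 log units; within the scatter), and putting it in place of 5-carboxypyridin-3-yl gives a 1.1-fold higher number from compound 1 to compound 3 (0.06 log units; within the scatter). This place on the saturated chain carbon bound to the ring amine nitrogen has now held a third group, one with a six-membered aromatic ring of carbon only, and all three compounds still read alike. Nothing measured here explains this result.

The compounds shown leave open whether a plain benzyl group with no carboxylic acid, or a benzyl group carrying an amine, would also stay within the scatter of these three. They also leave open whether a longer chain ending in the carboxylic acid would read the same.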